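From Methoxy to Chloro on a Shared Core

The source may hold more compounds than are shown below. What is called first, only, known or untested is meant among the compounds shown, and "the series" means these compounds.

In a functional assay on MCF7 cells (Homo sapiens) for cytotoxicity, read by MTT assay, with a stated time of 48 h (on this read-out lower numbers stand for stronger inhibition and higher numbers for weaker inhibition), three compounds with a shared core have been measured. Compound 1 `COc1ccccc1-c1nnc(SCCn2c([N+](=O)[O-])cnc2C)o1` gives 10800 nM, compound 2 `COc1ccc(-c2nnc(SCCn3c([N+](=O)[O-])cnc3C)o2)cc1` gives 10600 nM, and compound 3 `Cc1ncc([N+](=O)[O-])n1CCSc1nnc(-c2ccccc2F)o1` gives 20500 nM. Compound 2 therefore has no measured neighbour beyond the scatter: its smallest step is a 1.0-fold lower number from compound 1 to compound 2 (0.01 log units; within the scatter), and its largest is a 1.9-fold higher number from compound 2 to compound 3 (0.29 log units; within the scatter).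

Compound 4 `Cc1ncc([N+](=O)[O-])n1CCSc1nnc(-c2ccc(Cl)cc2)o1` keeps the core and differs from compound 2 in one group: chloro in place of methoxy on an aromatic carbon. This places chloro in place of methoxy on an aromatic carbon, turning 4-methoxyphenyl into 4-chlorophenyl. For the measured compounds named here, no chloro compound has yet been measured, so no step shows this exchange directly. The closest evidence comes from the two exchanges of a methoxy-bearing aryl group for a fluoro-bearing one, a 1.9-fold higher number from compound 1 to compound 3 (0.28 log units; within the scatter) and a 1.9-fold higher number from compound 2 to compound 3 (0.29 log units; within the scatter). The change from 2-methoxyphenyl to 4-methoxyphenyl, a 1.0-fold lower number from compound 1 to compound 2 (0.01 log units; within the scatter), also bears on it, since it concerns the same aryl group. All three steps stay within the scatter, so no step beyond the scatter is expected in this assay. The estimated step is a 1.3-fold higher number from compound 2 to compound 4 (0.12 log units; within the scatter), with the direction only tentative. Compound 4 is expected at 14000 nM, with an estimated range of 7000 nM to 28000 nM.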

Compound 4, half-maximal inhibitory concentration: 18700 nM
Beside the measured number, compound 4's estimate is 1.3-fold (0.13 log units) below it; low and high end bracket the measured number.
By their numbers in this assay, from the lowest: compounds 2, 1, 4 and 3 (each within the scatter of the next).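

Compound 4 brings the first chloro group onto the shared core, and in this assay the exchange of methoxy for chloro on this aromatic carbon, para to a large group, gives a 1.8-fold higher number from compound 2 to compound 4 (0.25 log units; within the scatter) and so remains within the usual scatter. For the compounds shown here, the other two new comparisons read the same way, with a 1.1-fold lower number from compound 3 to compound 4 (0.04 log units; within the scatter) and a 1.7-fold higher number from compound 1 to compound 4 (0.24 log units; within the scatter), which means that 2-methoxyphenyl, 4-methoxyphenyl, 2-fluorophenyl and 4-chlorophenyl cannot be told apart in this assay, and no compound among the four goes against this. Nothing available explains why these exchanges leave the number inside the scatter.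

Whether any group on this aromatic ring can carry the number beyond the scatter stays open, since the compounds shown bear only methoxy, fluoro and chloro there, and an amine, a carboxylic acid or a longer chain could read differently. The rest of the shared core is the same in all four compounds, so they also leave open how a change elsewhere on it would read.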